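Nitro-triazine series: cytotoxicity in canine kidney cells

The compounds below may be only part of what the source reports. "The series", "measured", "known", "first", "only" and "open" are said of these compounds alone.

Measured so far, in an ADME assay on MDCK cells (Canis lupus familiaris) for cytotoxicity; a higher number here means that more compound is tolerated, a lower number that less compound is tolerated:
compound 1 `O=[N+]([O-])C1=NNc2nc(C(F)(F)F)nn2C1c1c(O)cc(O)cc1O` gives 252000 nM
compound 2 `CSc1nc2n(n1)C(c1c(O)cc(O)cc1O)C([N+](=O)[O-])=NN2` gives 877000 nM
compound 3 `O=[N+]([O-])C1=NNc2nc(C(F)(F)F)nn2C1c1ccc(O)c(O)c1O` gives 67000 nM

Compound 3 has the lowest number of the three in this assay. The nearest is compound 1, whose number is higher by a step that lies beyond the scatter; compound 2 stands furthest away, again beyond the scatter. Compound 1 and compound 3 are built from the same atoms joined differently; the difference between the two cores is not broken down here.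

One change occurs twice among the compounds shown. From compound 1 to compound 2 it is methylsulfanyl in place of trifluoromethyl on an aromatic carbon, and in this assay it gave a 3.5-fold higher number from compound 1 to compound 2 (0.54 log units; beyond the scatter). The same change, on the core of compound 3, leads to compound 4 `CSc1nc2n(n1)C(c1ccc(O)c(O)c1O)C([N+](=O)[O-])=NN2`, which has not yet been measured in this assay: methylsulfanyl in place of trifluoromethyl on an aromatic carbon. The place line is the same word for word in both cases, so this is the same change.

The expectation for compound 4 rests on this single precedent. Because the earlier step was a 3.5-fold higher number from compound 1 to compound 2 (0.54 log units; beyond the scatter), compound 4 is expected to tolerate more compound than compound 3, with an estimated step of a 3.4-fold higher number from compound 3 to compound 4 (0.54 log units; beyond the scatter). Among the compounds with values here, with only one prior example of the change, the range is kept wide. Compound 4 is therefore estimated at 230000 nM in this assay, with a range from 100000 nM to 520000 nM.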

Compound 4, half-maximal cytotoxic concentration: 196000 nM
Compound 4: the middle estimate sits 1.2-fold (0.07 log units) above what was measured, and the stated range covers the measured number.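

In this assay, methylsulfanyl in place of trifluoromethyl on an aromatic carbon gave a 2.9-fold higher number from compound 3 to compound 4 (0.47 log units; beyond the scatter), and set against the earlier step the change holds in direction and in size: the same change on two cores in this assay, a 3.5-fold higher number (0.54 log units; beyond the scatter) from compound 1 to compound 2 and a 2.9-fold higher number (0.47 log units; beyond the scatter) from compound 3 to compound 4, 1.2-fold (0.08 log units) apart, within the scatter of two such steps For these two cores, then, the step measured on one core served as a fair guide to the step on the other, and the difference in how the shared atoms are joined did not alter what the change did in this assay. This does not show that the change would carry to cores beyond these two, since it rests on two pairs only, both with the same nitro-bearing ring and both with a hydroxyl-bearing phenyl group, and it gives no reason for the step in either pair.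

The compounds shown put only trifluoromethyl and methylsulfanyl on the aromatic carbon between two ring nitrogen atoms, so it remains open how an amine, a carboxylic acid or a longer sulfur-linked chain such as ethylsulfanyl would fare there. From the compounds shown here alone, it also remains open whether the step would persist if the nitro group gave way to a nitrile, or if the hydroxyl groups on the phenyl ring were replaced by methoxy groups.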